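A methyl on the amide-type nitrogen of compound 3

The source may hold more compounds than are shown below. What is called first, only, known or untested is meant among the compounds shown, and "the series" means these compounds.

Among the measured compounds shown here, in a functional assay on the whole organism with Mus musculus as the target (on this read-out higher numbers stand for an effect only at larger amounts of compound and lower numbers for an effect already at smaller amounts), compound 1 `CCC(O)CNC(=O)/C=C/c1cccc(C(F)(F)F)c1` gives 90 mg/kg as the only true number among the measured compounds. Compound 2 `CN1CCN(C(=O)/C=C/c2cccc(C(F)(F)F)c2)CC1` has > 100 mg/kg as its result, and that is a limit. Compound 3 `O=C1CCC(O)(c2cccc(C(F)(F)F)c2)N1` has > 200 mg/kg as its result, again a limit and not a number, so it cannot be ranked exactly against the other two.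

Compound 4 `CN1C(=O)CCC1(O)c1cccc(C(F)(F)F)c1` differs from compound 3 in one place: methyl in place of hydrogen on an amide-type nitrogen in a ring with methyl in place of hydrogen on an amide-type nitrogen in a ring.

For the measured compounds named here, only one measured step exists, an at least 1.1-fold higher number from compound 1 to compound 2 (0.04 log units; that floor lies within the scatter) for 4-methylpiperazin-1-yl in place of (2-hydroxybutyl)amino on a carbonyl carbon. That step sits on a different core and its floor lies within the scatter, so it offers no size to carry over to the new change. No step beyond the scatter, in either direction, is expected in this assay and a number no higher from compound 3 to compound 4 (the limit leaves the size open) is the estimated step. For compound 4 the estimate is 200 mg/kg with an expected range from 90 mg/kg to 400 mg/kg as the upper end. Another limit is about as likely as a true number.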

Compound 4, dose for half-maximal effect: 129 mg/kg
Estimate against measurement, compound 4: 1.6-fold (0.19 log units) above, within the range that was stated.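

In this assay compound 3 stands at > 200 mg/kg, which is a limit of the assay and not a number. Methyl in place of hydrogen on the amide-type nitrogen in a ring gives an at least 1.5-fold lower number from compound 3 to compound 4 (0.19 log units; that floor lies within the scatter), so this position accepts a small carbon group, and this core now has its first true number, though the smallest size the step can have does not clear the usual scatter of repeated measurements. The true size of the step stays unknown, and it may be well beyond that scatter or barely there, because its starting point is only a limit: the limit of > 200 mg/kg in this assay, at which 1 of the 4 values shown sits.

The compounds shown leave open whether an ethyl group or a longer chain on this same nitrogen would move the dose further, and in which direction. Also open, from the compounds shown here alone, is whether the methyl step would look the same with an amine or a methoxy group in place of the hydroxy group, on the ring atom that now bears it.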